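The source may report more compounds than this note shows. Statements on the series, on what has been measured and on what is new or still open speak of the compounds shown alone.

Measured so far:
compound 1 `Cc1ccc(C(=O)n2c(-c3cn(-c4ccccc4)nc3-c3ccc(F)cc3)nc3ccccc32)cc1` — 178000 nM
compound 2 `Cc1ccc(-c2nn(-c3ccccc3)cc2-c2nc3ccccc3n2C(=O)c2cncc(C)c2)cc1` — 155000 nM

In an ADME assay on HEK-293T cells (Homo sapiens) for cytotoxicity, read by MTT assay, with a stated time of 24 h (a lower number here means that less compound is tolerated, a higher number that more compound is tolerated), compound 2 gives 155000 nM, the lower of the two numbers; the nearest is compound 1, whose difference from it lies within the scatter. Compound 3 `Cc1ccc(C(=O)n2c(-c3cn(-c4ccccc4)nc3-c3ccc(C)cc3)nc3ccccc32)cc1` differs from compound 2 by 4-methylphenyl in place of 5-methylpyridin-3-yl on a carbonyl carbon. Among the compounds with values here, no step between two measured compounds isolates this change, so the size of the step in this assay is uncertain. Since compounds 1 and 2 sit together, no step beyond the scatter is expected from compound 2 to compound 3. Compound 3 is estimated at 170000 nM, within 85000 nM to 340000 nM, meaning an expected step of a 1.1-fold higher number from compound 2 to compound 3 (0.04 log units; within the scatter).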

Compound 3, half-maximal cytotoxic concentration: 176000 nM
Compound 3: the middle estimate sits 1.0-fold (0.02 log units) below what was measured; low and high end bracket the measured number.
By their numbers in this assay, from the lowest: compounds 2, 3 and 1 (each within the scatter of the next).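

With 4-methylphenyl in place of 5-methylpyridin-3-yl on a carbonyl carbon, this assay shows a 1.1-fold higher number from compound 2 to compound 3 (0.06 log units; within the scatter) at this position, so exchanging these two rings leaves the number within the scatter. Methyl in place of fluoro on an aromatic carbon shows a 1.0-fold lower number from compound 1 to compound 3 (0.00 log units; within the scatter) and likewise gives no step beyond the scatter. No measurement available here explains either step. All three compounds carry an aromatic ring on the carbonyl carbon. On these data alone, whether an amine or a carboxylic acid on that ring, or a longer chain in its place, would leave the number similarly unmoved remains open.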